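This account rests on a few compounds, and the source may have more. Where it says the series, first, only, none or still open, it means among the compounds named here.

Measured compounds:
- compound 1, `COc1ccccc1/C=c1/[nH]c(=O)/c(=C\c2ccccc2OC)[nH]c1=O`: "not active" (no number reported)
- compound 2, `C=CCn1c(=O)/c(=C\c2ccc(Cl)c(Cl)c2)[nH]c(=O)/c1=C\c1ccccc1`: "not active" (no number reported)
- compound 3, `COc1ccccc1/C=c1\c(=O)[nH]/c(=C/c2ccccc2Cl)c(=O)n1C`: 200 nM

In a functional assay on NCI-H1975 cells (Homo sapiens) for cytotoxicity, read by CCK-8 assay, with a stated time of 72 h (a lower number here means a stronger inhibitor, a higher number a weaker inhibitor), compound 3 gives 200 nM. Among the measured compounds shown here, compound 1 gives "not active" (no number reported) in this assay, and compound 2 gives "not active" (no number reported) there; for neither of these two is a number reported, so compound 3 holds the only number in the set and cannot be ranked against the other two beyond the bare fact that it is the one with a measurable read-out.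

For the measured compounds named here, no pair of measured compounds differs in only one place, so no measured step is available. The next compound, compound 4, is `C=CCn1c(=O)/c(=C\c2ccccc2Cl)[nH]c(=O)/c1=C\c1ccccc1OC`. It differs from compound 3 by vinyl in place of hydrogen on a saturated chain carbon bound to an aromatic nitrogen. Compound 2 also carries the allyl group but differs from compound 3 in its other two benzylidene rings, so it says nothing direct about this change.

Without a measured step the expected step from compound 3 to compound 4 in this assay rests on the change alone: a small weakening is estimated, a 2.0-fold higher number from compound 3 to compound 4 (0.30 log units; within the scatter), close to the scatter. For compound 4 the estimated value in this assay is 400 nM, with a range from 120 nM to 2000 nM.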

Compound 4, half-maximal inhibitory concentration: 9200 nM
Compound 4: middle estimate off by 23-fold (1.36 log units), on the low side, and the stated range ends below it.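

Among the compounds shown here, replacing methyl with allyl on the saturated chain carbon bound to an aromatic nitrogen gives the first measured step: in this assay, the change gives a 46-fold higher number from compound 3 to compound 4 (1.66 log units; beyond the scatter) and lies beyond the scatter. The read-out is therefore sensitive to the group at this place. The earlier compounds shown here could not establish this point, as no two of them differed in only one place. Compound 4 still gives a measured 9200 nM with the allyl group in place, but nothing available explains the size of this step.

From the compounds shown here alone, it remains open whether the step follows from the added chain length or from the double bond of the allyl group; a saturated propyl chain at the same place would separate the two, and an ethyl chain would show whether a smaller extension beyond methyl already carries part of the step. Also open, going by these compounds, is how this place responds to groups of a different kind, such as a hydroxyethyl chain, an aminoethyl chain or a carboxylic acid on a short chain.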